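Spirocyclic amide series: heteroaryl swap at the amine nitrogen

This account rests on a few compounds, and the source may have more. Where it says the series, first, only, none or still open, it means among the compounds named here.

compound 1 `Cc1ccnc(NC[C@@H]2CC3(CC3)CN2C(=O)c2nc(C)sc2-c2ccccc2)n1` — 7
compound 2 `O=C(c1cc(Cl)ccc1-c1ncccn1)N1CC2(CC2)C[C@H]1CNc1cc(C(F)(F)F)ccn1` — 7.1
compound 3 `Cc1nc(C(=O)N2CCC3(CC3)C[C@H]2CNc2ccc(Cl)cn2)c(-c2ccccc2)s1` — < 5 (a limit)

In a functional assay on HEK293 cells for antagonist activity at Orexin receptor type 2 (Homo sapiens), read by FLIPR and calcium flux (on this read-out lower numbers stand for lower potency and higher numbers for higher potency (the scale is a negative logarithm)), compound 1 gives 7, the lower of the two numbers available. Compound 2 gives 7.1, which lies within the scatter of compound 1, so no order between the two can be read. Compound 3 returns only a limit in this assay, < 5 (the limit of < 5 in this assay, at which 1 of the 3 values shown sits). Within the data shown here, no pair of measured compounds differs in a single place, so no measured step is available; compound 2 and compound 3 each differ from compound 1 at more than one site.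

Compound 4 `Cc1nc(C(=O)N2CC3(CC3)C[C@H]2CNc2ccc(C(F)(F)F)cn2)c(-c2ccccc2)s1` keeps the core of compound 1 and changes one group: 5-(trifluoromethyl)pyridin-2-yl in place of 4-methylpyrimidin-2-yl on an amine nitrogen. Compound 2 carries a trifluoromethyl-substituted pyridinyl on the same amine nitrogen and gives 7.1, on a different amide. No step beyond the scatter is expected; the step of no change at the digits printed from compound 1 to compound 4 (within the scatter) is estimated as small. Compound 4 is expected at 7, with a range from 6.3 to 7.7.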

Compound 4, negative logarithm of the antagonist equilibrium constant: 7.7
The estimate for compound 4 lay 0.70 log units below the measured number; low and high end bracket the measured number.
By their numbers in this assay, from the lowest: compounds 1 and 2 (each within the scatter of the next); then compound 4. At a limit, below all of these: compound 3.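

In this assay, the heteroaryl group on the amine nitrogen now has a single-place step to its name, and it reads a number 0.70 log units higher from compound 1 to compound 4 (beyond the scatter). So this position responds to the change from 4-methylpyrimidin-2-yl to 5-(trifluoromethyl)pyridin-2-yl, which the earlier compounds, differing at more than one site, could not show. No measurement shown here accounts for the step.

On these data alone, the change alters the ring and its substituent together, so their separate shares in the step stay open; a pyrimidine ring carrying trifluoromethyl on the same amine nitrogen would help to separate them. Also open, as far as these compounds go, is whether the trifluoromethyl group itself matters or whether a nitrile or a methoxy group on the pyridine ring would serve equally well.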